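The compounds below may be only part of what the source reports. "The series", "measured", "known", "first", "only" and "open" are said of these compounds alone.

Measured so far:
compound 1, `COc1cc2c(cc1OC)C(CC(=O)Nc1ccc(Cl)cc1)CC2`: 71.9%
compound 2, `COc1cc2c(cc1OC)C(CC(=O)Nc1cccc(C)c1)CC2`: 37.5%

Both numbers come from a functional assay on the whole organism (strain Wistar) for inhibition, with Rattus norvegicus as the target, read by paw edema, with a stated time of 1 h, at a dose of 100 mg/kg; on this read-out higher numbers stand for more inhibition at the one dose given (going by the name of the read-out) and lower numbers for less inhibition. Among the measured compounds shown here, compound 2 stands lowest of the two, with compound 1 the nearest and higher; the single measured step, a number 34.4 percentage points lower from compound 1 to compound 2 (beyond the scatter), is large and beyond the scatter. Compound 3, `COc1cc2c(cc1OC)C(CC(=O)Nc1ccc(C)cc1)CC2`, differs from compound 2 by 4-methylphenyl in place of 3-methylphenyl on an amide-type nitrogen. For the measured compounds named here, no measured step moves a methyl from one ring position to another; the one known step changes both the group and its place at once, so it bears on compound 3 only loosely. The direction of a number 34.4 percentage points lower from compound 1 to compound 2 (beyond the scatter), where the compound carrying 4-chlorophenyl gives the higher number, hints at most that a 4-methylphenyl may sit above compound 2, but the size cannot be read from it. Compound 3 is therefore expected to give 50%, within 30% to 72%, an estimated step of a number 12.5 percentage points higher from compound 2 to compound 3 (beyond the scatter) with wide uncertainty.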

Compound 3, a percentage reported as inhibition, in the whole organism at one dose (the size of the read-out at that dose, not a potency): 34.4%
The estimate for compound 3 lay 15.6 percentage points above the measured number; measured number inside the range.
By their numbers in this assay, from the lowest: compounds 3 and 2 (each within the scatter of the next); then compound 1.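

In this assay, moving the methyl on the ring attached to the amide-type nitrogen from 3-methylphenyl to 4-methylphenyl gives a number 3.1 percentage points lower from compound 2 to compound 3 (within the scatter), so these compounds do not separate the two methyl placements. The comparison of compound 1 and compound 3 changes only the group on the aromatic carbon and gives a number 37.5 percentage points lower from compound 1 to compound 3 (beyond the scatter), which ties the large gap to chloro against methyl with the ring placement held, something the step from compound 1 to compound 2 could not do, as it changed group and placement together. No measurement to hand bears on the reason for this gap.

Going by these compounds, whether chloro keeps its higher number away from the 4-chlorophenyl placement remains open, and a 3-chlorophenyl group would address this. Where 4-fluorophenyl or 4-methoxyphenyl would fall relative to compound 1 and compound 3 is also open.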